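Aryl variation on the shared core: three measured, one pending

The source may hold more compounds than are shown below. What is called first, only, known or untested is meant among the compounds shown, and "the series" means these compounds.

Measured compounds and their values:
compound 1, `CS(=O)(=O)c1ccc(-c2cnc3[nH]cc(-c4nnc(-c5ccncc5)o4)c(=O)c3c2)cc1`: 5.61% in a functional assay on HCT-116 cells (Homo sapiens) for inhibition, read by MTT assay, with a stated time of 24 h, tested at 5 uM; on this read-out higher numbers stand for more inhibition of growth at the one concentration tested and lower numbers for less inhibition of growth
compound 2, `CS(=O)(=O)c1ccc(-c2cnc3[nH]cc(-c4nnc(-c5ccc(F)cc5)o4)c(=O)c3c2)cc1`: 14.9% in this assay
compound 3, `CS(=O)(=O)c1ccc(-c2cnc3[nH]cc(-c4nnc(-c5ccccc5)o4)c(=O)c3c2)cc1`: 8.6% in this assay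

Compound 3 stands second highest of the three numbers. Its nearest neighbour is compound 1, with the step of a number 3 percentage points higher from compound 1 to compound 3 (within the scatter); its furthest is compound 2, with the step of a number 6.3 percentage points lower from compound 2 to compound 3 (within the scatter). The remaining pair gives a number 9.3 percentage points higher from compound 1 to compound 2 (within the scatter). None of the three steps leaves the scatter, so the three aryl groups on the five-membered ring cannot be ranked on these numbers.

Compound 4, `CS(=O)(=O)c1ccc(-c2cnc3[nH]cc(-c4nnc(-c5ccccn5)o4)c(=O)c3c2)cc1`, differs from compound 3 in one place: pyridin-2-yl in place of phenyl on an aromatic carbon. The step that bears most directly on it is the exchange of pyridin-4-yl for phenyl, a number 3 percentage points higher from compound 1 to compound 3 (within the scatter), which was within the scatter; the other aryl swaps, a number 9.3 percentage points higher from compound 1 to compound 2 (within the scatter) and a number 6.3 percentage points lower from compound 2 to compound 3 (within the scatter), were likewise within the scatter. No step beyond the scatter is therefore expected in this assay for the move from phenyl to pyridin-2-yl, in either direction.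

The expected step is a number 1.6 percentage points lower from compound 3 to compound 4 (within the scatter). For compound 4 the estimate in this assay is 7%, with a range from -2% to 16%.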

Compound 4, percent growth inhibition at one concentration: 11.3%
Beside the measured number, compound 4's estimate is 4.3 percentage points below it; the measured number falls inside the stated range.
By their numbers in this assay, from the lowest: compounds 1, 3, 4 and 2 (each within the scatter of the next).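

In this assay, pyridin-2-yl gives a fourth aryl group at this position, and all three of its steps stay within the scatter: a number 2.7 percentage points higher from compound 3 to compound 4 (within the scatter), a number 3.6 percentage points lower from compound 2 to compound 4 (within the scatter) and a number 5.7 percentage points higher from compound 1 to compound 4 (within the scatter). Going by these compounds alone, the last step is the first comparison of two pyridine isomers on this carbon, and neither it nor the exchange of phenyl for pyridin-2-yl, which enters a hydrogen-bond acceptor, gives a readable change, so the four aryl groups remain unranked. No measured evidence accompanying these numbers accounts for them.

From the compounds shown here alone, all four compounds carry a six-membered aromatic ring here, so it remains open whether a piperidine, a carboxylic acid or a short alkyl chain on this carbon would move the number beyond the scatter. Going by these compounds, it also remains open whether the aryl groups would separate at other concentrations in this assay.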